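Para substituent on the benzyl ether: isopropyl to cyano

The compounds below may be only part of what the source reports. "The series", "measured", "known", "first", "only" and "open" are said of these compounds alone.

Measured so far in a functional assay on HEK293 cells for agonist activity at G-protein coupled receptor 39 (Homo sapiens), read by scintillation proximity assay and inositol phosphate accumulation, with a stated time of 75 min; a higher number here means that more compound is needed for the effect, a lower number that less compound is needed:
compound 1 `Cc1nn(-c2ncnc3nc[nH]c23)c2c1C(OCC(=O)c1ccc(F)cc1)CC(=O)N2` gives 973 nM
compound 2 `Cc1nn(-c2ncnc3nc[nH]c23)c2c1C(OCc1ccccc1F)CC(=O)N2` gives 78 nM
compound 3 `Cc1nn(-c2ncnc3nc[nH]c23)c2c1C(OCc1ccc(C(C)C)cc1)CC(=O)N2` gives 1690 nM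

Compound 3 sits at the top end of these three numbers. Its separation from compound 1 is not a real one, since a 1.7-fold higher number from compound 1 to compound 3 (0.24 log units; within the scatter) lies within the scatter; its separation from compound 2 is, since a 22-fold higher number from compound 2 to compound 3 (1.34 log units; beyond the scatter) lies well beyond it. The step from compound 1 to compound 2, a 12-fold lower number from compound 1 to compound 2 (1.10 log units; beyond the scatter), shows that the group on the ether-bearing chain carbon can move the number a great deal.

Compound 4 `Cc1nn(-c2ncnc3nc[nH]c23)c2c1C(OCc1ccc(C#N)cc1)CC(=O)N2` differs from compound 3 in one place: cyano in place of isopropyl on an aromatic carbon. Within the data shown here, no measured step exchanges one group for another at this para position while leaving the benzyl ether intact; the only step that touches this phenyl, from compound 2 to compound 3, changes group and ring position together. The size and direction of the step in this assay are therefore uncertain. A modest shift toward a lower number is expected, a 2.1-fold lower number from compound 3 to compound 4 (0.32 log units; beyond the scatter), with compound 4 estimated at 800 nM, within a range of 200 nM to 3200 nM.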

Compound 4, half-maximal effective concentration: 60 nM
The estimate for compound 4 lay 13-fold (1.12 log units) above the measured number; measured number outside the range, below it.
By their numbers in this assay, from the lowest: compounds 4 and 2 (each within the scatter of the next); then compounds 1 and 3 (each within the scatter of the next).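

In this assay the group at this position matters on its own: with the benzyl ether intact and the ring position unchanged, cyano in place of isopropyl gives a large step (a 28-fold lower number from compound 3 to compound 4 (1.45 log units; beyond the scatter)), whereas the earlier step through this phenyl changed group and ring position together. The 4-cyanophenyl group also matches the 2-fluorophenyl group (a 1.3-fold lower number from compound 2 to compound 4 (0.11 log units; within the scatter)), and it stands well apart from the (4-fluorophenyl)carbonyl group (a 16-fold lower number from compound 1 to compound 4 (1.21 log units; beyond the scatter)). No measurement at hand bears on what lies behind the cyano step.

The compounds shown leave open how an amine, a carboxylic acid or a methoxy group at this position would compare with cyano and isopropyl. They also leave open whether a single fluorine here would give a number close to that of the nitrile.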